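Swapping the bromophenyl hydrazide for a propyl amide

The source may report more compounds than this note shows. Statements on the series, on what has been measured and on what is new or still open speak of the compounds shown alone.

The series shares the core seen in compound 1 `NNC(=O)c1c(NC(=O)NS(=O)(=O)c2ccccc2)sc2c1CCCCC2`, a sulfonylurea bearing a carbohydrazide arm. In a functional assay on cells (Cancer cell lines, Homo sapiens) for inhibition, with a stated time of 48 h (a lower number here means a stronger inhibitor of growth, a higher number a weaker inhibitor of growth), compound 1 gives only a limit of the assay, > 100000 nM. Compound 2 `O=C(Nc1sc2c(c1C(=O)NNc1ccc(Br)cc1)CCCCC2)NS(=O)(=O)c1ccccc1` carries a 4-bromophenyl group on the terminal amine nitrogen, and in this assay compound 2 gives 25500 nM. This is the only number shown in the set; the other value is a limit, so compound 2 stands alone as the one compound with a measured concentration for growth inhibition. For the measured compounds named here, the step of an at least 3.9-fold lower number from compound 1 to compound 2 (0.59 log units; beyond the scatter) is the only measured step, and it was at least modest.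

Compound 3 `CCCNC(=O)c1c(NC(=O)NS(=O)(=O)c2ccccc2)sc2c1CCCCC2` differs from compound 2 by propyl in place of (4-bromophenyl)amino on an amide-type nitrogen. Going by the values given here, no measured step covers this exact change. Among the compounds with values here, the one step available runs the other way: adding the 4-bromophenyl group to compound 1 gave a lower number, so taking it away and leaving a short chain is expected to move the number back up. Compound 3 is estimated to give 60000 nM, within 20000 nM to 150000 nM, a step of a 2.4-fold higher number from compound 2 to compound 3 (0.37 log units; beyond the scatter) that is expected to exceed the scatter.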

Compound 3, concentration for 50% growth inhibition: 72500 nM
Beside the measured number, compound 3's estimate is 1.2-fold (0.08 log units) below it, and the stated range covers the measured number.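

The new value shows that this amide-type nitrogen does not need the (4-bromophenyl)amino group to give a measurable number, but that the group counts for something here: with propyl in its place, this assay shows a 2.8-fold higher number from compound 2 to compound 3 (0.45 log units; beyond the scatter). For the compounds shown here, this is the first comparison of the aryl hydrazide with a simple chain, and it leaves compound 2 with the lower number of the two measured compounds, although the step is only modest. Propyl in place of amino gives an at least 1.3-fold lower number from compound 1 to compound 3 (0.13 log units; that floor lies within the scatter), and no real gain over amino can be claimed from this floor because the value for compound 1 is a limit of the assay: the limit of > 100000 nM in this assay, at which 1 of the 3 values shown sits.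

The compounds shown do not separate the contributions of the bromine, the aromatic ring and the extra nitrogen of the (4-bromophenyl)amino group, and a phenylamino group without bromine or a benzyl group directly on the amide nitrogen would pull these apart. As far as these compounds go, it also stays open whether a longer chain such as hexyl in place of propyl would bring the number closer to that of compound 2.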